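The compounds below may be only part of what the source reports. "The series", "measured", "known", "first", "only" and "open" are said of these compounds alone.

In a physicochemical assay for lipophilicity, at pH 7.4 (on this read-out higher numbers stand for higher lipophilicity and lower numbers for lower lipophilicity), compound 1 (`CNC(=O)c1cc(C(=O)N[C@H]2[C@@H]3COC[C@@H]32)cc2c1OC[C@H]2c1cccc2[nH]ccc12`) gives 3.1 and compound 2 (`CNC(=O)c1cc(C(=O)N[C@H]2[C@@H]3COC[C@@H]32)cc2c1OC[C@H]2c1ccccc1`) gives 3.3 while compound 3 (`CNC(=O)c1cc(C(=O)N[C@H]2[C@@H]3C[C@@H](O)C[C@@H]32)cc2c1OC[C@H]2c1ccccc1`) gives 2.9 on the same read-out. Compound 3 and compound 1 lie within the scatter of each other, whereas the step of a number 0.40 log units lower from compound 2 to compound 3 (beyond the scatter) lies beyond it.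

Compound 4 (`CCC(=O)N1C[C@@H]2[C@H](C1)[C@H]2NC(=O)c1cc(C(=O)NC)c2c(c1)[C@H](c1ccccc1)CO2`) has not yet been measured. Compared with compound 3 it carries a different group on an amide-type nitrogen (a group of 10 heavy atoms (8 carbon, 1 nitrogen, 1 oxygen; one three-membered non-aromatic ring of carbon only, one five-membered non-aromatic ring with 1 hetero atom) in place of a group of 7 heavy atoms (6 carbon, 1 oxygen; one three-membered non-aromatic ring of carbon only, one five-membered non-aromatic ring of carbon only), on an amide-type nitrogen). Among the compounds with values here, only one measured step bears directly on this place, the modest a number 0.40 log units lower from compound 2 to compound 3 (beyond the scatter) on the same kind of nitrogen. The step of a number 0.20 log units higher from compound 1 to compound 2 (within the scatter) concerns a saturated ring carbon instead and offers little guidance here. Within the data shown here, no measured compound yet carries the incoming group, so the direction of any change remains uncertain. In this assay the expected change is a step of a number 0.10 log units higher from compound 3 to compound 4 (within the scatter) that stays within the scatter. For compound 4 the estimated value is 3 with an expected range from 2.6 to 3.4 in this measurement.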

Compound 4, distribution coefficient: 3.4
The estimate for compound 4 lay 0.40 log units below the measured number; low and high end bracket the measured number.
By their numbers in this assay, from the lowest: compounds 3, 1, 2 and 4 (each within the scatter of the next, the first and the last beyond it).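

In this assay the amide-type nitrogen now shows movement in both directions, with a number 0.50 log units higher from compound 3 to compound 4 (beyond the scatter) standing against the earlier a number 0.40 log units lower from compound 2 to compound 3 (beyond the scatter) at the same place. The group of 10 heavy atoms and the group of 6 heavy atoms cannot be told apart, with a number 0.10 log units higher from compound 2 to compound 4 (within the scatter), so across these three compounds the heavy-atom count does not order the read-out, and compound 3 alone stands apart from the other two. No measured information accounts for this difference and the compounds shown give no reason for it. Going by these compounds, whether a group carrying an amine or a carboxylic acid at this nitrogen would fall with compound 3 or with compound 2 and compound 4 remains open. A longer chain in the group of compound 4 is equally untested among the compounds shown.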